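Replacing the amine substituent of compound 3 with hydrogen

The source may report more compounds than this note shows. Statements on the series, on what has been measured and on what is new or still open speak of the compounds shown alone.

In a functional assay on HepG2 cells (Homo sapiens) for inhibition, read by MTT assay, with a stated time of 48 h (a higher number here means a weaker inhibitor, a lower number a stronger inhibitor), compound 1 `CCOC(=O)C1=C(N/N=C(/C(=O)Br)c2ccc(Br)cc2)Nc2[nH]nc(C)c2C1c1ccc(N(C)C)cc1` gives 65000 nM while compound 2 `CCOC(=O)C1=C(N/N=C(/Br)c2ccccc2)Nc2[nH]nc(C)c2C1c1ccc(N(C)C)cc1` gives 72000 nM and compound 3 `CCOC(=O)C(=NNC1=C(C(=O)OCC)C(c2ccc(N(C)C)cc2)c2c(C)n[nH]c2N1)C(=O)OCC` gives 80800 nM in the same test. Compound 3 therefore stands level with the other two within the scatter. Compound 4 `CCOC(=O)C1=C(N)Nc2[nH]nc(C)c2C1c1ccc(N(C)C)cc1` differs from compound 3 by a hydrogen atom in place of a group of 12 heavy atoms (7 carbon, 1 nitrogen, 4 oxygen; no ring), on an amine nitrogen and by nothing else. Among the measured compounds shown here, three measured steps bear on this change, all at the same amine nitrogen. These are a 1.2-fold higher number from compound 1 to compound 3 (0.09 log units; within the scatter) and a 1.1-fold higher number from compound 2 to compound 3 (0.05 log units; within the scatter) along with a 1.1-fold higher number from compound 1 to compound 2 (0.04 log units; within the scatter) and none goes beyond the scatter. On these data alone, each of them swaps one sizeable group for another, and none leaves a hydrogen atom on that nitrogen, so the replacement itself is untested. No step beyond the scatter is expected in either direction, though the uncertainty is wide. The expected step is a 1.1-fold lower number from compound 3 to compound 4 (0.03 log units; within the scatter) as an estimate. In this assay compound 4 is expected at 75000 nM (estimated range 30000 nM to 190000 nM).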

Compound 4, half-maximal inhibitory concentration: 4240 nM
For compound 4 the middle estimate is 18-fold (1.25 log units) above the measured one; the whole stated range lies above it.
By their numbers in this assay, from the lowest: compound 4; then compounds 1, 2 and 3 (each within the scatter of the next).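

In this assay, the amine nitrogen bearing only hydrogen sets compound 4 apart from all three substituted compounds, with a 19-fold lower number from compound 3 to compound 4 (1.28 log units; beyond the scatter), a 17-fold lower number from compound 2 to compound 4 (1.23 log units; beyond the scatter) and a 15-fold lower number from compound 1 to compound 4 (1.19 log units; beyond the scatter). The earlier compounds had shown only that the three large groups could stand in for one another within the scatter, whether or not they carried a ring; the new steps show that this flat stretch does not extend to the unsubstituted amine, so at this position having no such group counts for far more than which of the three is present. No measurement shown gives a reason for this difference.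

The compounds shown hold nothing between hydrogen and these large groups, so it remains open whether a single methyl or an acetyl on that nitrogen would keep the number of compound 4 or return to that of the others. Whether a second amine substituent or a longer alkyl chain would fit either outcome is equally unsettled.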